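A few compounds are considered here, and "the series" means these few. Any claim that something is new, unique, unknown or untested is made for them only; others in the source may bear on it.

In a functional assay on HL-60 cells (Homo sapiens) for inhibition, read by CCK-8 assay, with a stated time of 48 h (on this read-out higher numbers stand for weaker inhibition and lower numbers for stronger inhibition), compound 1 `O=C(NCCNS(=O)(=O)c1ccc(-c2ccccc2Oc2ccc(O)c(O)c2)s1)Nc1cc(Cl)cc(Cl)c1` gives 10400 nM. Compound 2 `O=[N+]([O-])c1ccc(Oc2ccccc2-c2ccc(S(=O)(=O)NCCNC(=S)Nc3cccc(Cl)c3)s2)cc1` reaches only a limit of the measurement, > 50000 nM, so no number is known for it, as the limit of > 50000 nM in this assay, at which 1 of the 3 values shown sits, records. Compound 3 `O=C(NCCNS(=O)(=O)c1ccc(-c2ccccc2O[C@H]2CC[C@@H](O)CC2)s1)Nc1cc(C(F)(F)F)cc(C(F)(F)F)c1` gives 3100 nM, the lowest of the two numbers, and its gap to compound 1 lies beyond the usual scatter. Compound 4 `O=C(NCCNS(=O)(=O)c1ccc(-c2ccccc2OCc2cccc(O)c2)s1)Nc1cc(C(F)(F)F)cc(C(F)(F)F)c1` has not yet been measured. It differs from compound 3 in one place: 3-hydroxybenzyl in place of 4-hydroxycyclohexyl on an oxygen on an aromatic ring. Within the data shown here, no measured pair of this kind is available to lean on, so the step of a 1.1-fold higher number from compound 3 to compound 4 (0.05 log units; within the scatter) is expected to be small, in either direction, and not clearly beyond the scatter. Compound 4 is estimated at 3500 nM, with a likely range from 1200 nM to 10000 nM.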

Compound 4, half-maximal inhibitory concentration: 4000 nM
Compound 4: middle estimate off by 1.1-fold (0.06 log units), on the low side, within the range that was stated.
By their numbers in this assay, from the lowest: compounds 3 and 4 (each within the scatter of the next); then compound 1. At a limit, above all of these: compound 2.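

In this assay, the change from 4-hydroxycyclohexyl to 3-hydroxybenzyl gives a 1.3-fold higher number from compound 3 to compound 4 (0.11 log units; within the scatter) and so separates the two groups by no more than repeat measurements would. At this position on the oxygen, then, a non-aromatic carbon ring with two defined stereocentres and an aromatic ring give matching results in this pair. No measurement shown bears on why the two groups match. Still open, as far as these compounds go, is whether an amine or a carboxylic acid in place of the hydroxyl, or a longer chain on the oxygen, would give a different value.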